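The compounds below may be only part of what the source reports. "The series", "measured", "known", "first", "only" and "open" are said of these compounds alone.

Three esters on closely related cores have results in a functional assay on HCT-15 cells (Homo sapiens) for antiproliferative activity, read by sulforhodamine B assay, with a stated time of 48 h, tested at 50 uM; on this read-out lower numbers stand for less inhibition and higher numbers for more inhibition at the one concentration tested (going by the name of the read-out). Compound 2 `CC1=CC[C@H](C(C)C)c2cc(C)c(OC(=O)c3ccc(Cl)cc3)cc21` gives 47.4%, the highest of the two reported numbers. Compound 3 `CC1=CC[C@H](C(C)C)c2cc(C)c(OC(=O)c3cccc(C(F)(F)F)c3)cc21` gives 15%, a gap beyond the usual scatter relative to compound 2. Compound 1 `Cc1cc2c(C(C)C)ccc(C)c2cc1OC(=O)c1cccc(C(F)(F)F)c1` is reported as "not active" (no number reported) with no number attached. Compound 4 `CC1=CC[C@H](C(C)C)c2cc(C)c(OC(=O)c3ccc(C)cc3)cc21` has not yet been run in this assay. It differs from compound 2 in one spot: methyl in place of chloro on an aromatic carbon. Going by the values given here, no measured pair isolates this exchange, so the step has no direct precedent here; a modest downward move, near the edge of the scatter, is the working expectation. The expected step is a number 12.4 percentage points lower from compound 2 to compound 4 (beyond the scatter). Compound 4 is estimated at 35%, with a range from 15% to 55%.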

Compound 4, a percentage reported as inhibition, at one concentration (the size of the read-out at that concentration, not a potency): 78.9%
Compound 4: the middle estimate sits 43.9 percentage points below what was measured; the whole stated range lies below it.
By their numbers in this assay, from the lowest: compound 3; then compound 2; then compound 4.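

Going by these compounds alone, this is the first pair that differs in one place, and in this assay the change from 4-chlorophenyl to 4-methylphenyl gives a number 31.5 percentage points higher from compound 2 to compound 4 (beyond the scatter). The result at this position, para to a large group, therefore depends strongly on which group sits there, even though both groups count one heavy atom and neither carries a hydrogen-bond donor or acceptor. Nothing shown here gives a cause for this step.

Open, on these data alone, is how a methoxy group, an amine or a longer alkyl chain at this position would read out. Also open, as far as these compounds go, is whether the 4-methylphenyl ester keeps its result on the core of compound 1.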